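Series notes: aryl swap on the shared core

A few compounds are considered here, and "the series" means these few. Any claim that something is new, unique, unknown or untested is made for them only; others in the source may bear on it.

Three compounds have numbers in a functional assay on MCF7 cells (Homo sapiens) for inhibition, read by sulforhodamine B assay, with a stated time of 72 h; a lower number here means a stronger inhibitor, a higher number a weaker inhibitor. Compound 1 `Cc1ccc(C2=Nn3c(nnc3C(C)c3ccc(CC(C)C)cc3)SC2)cc1` gives 6300 nM. Compound 2 `CC(c1ccc(-c2ccccc2)c(F)c1)c1nnc2n1N=C(c1ccc(OC(F)(F)F)cc1)CS2` gives 4800 nM, the lowest number of the three. Compound 3 `COc1ccc2cc(C(C)c3nnc4n3N=C(c3ccc(Br)cc3)CS4)ccc2c1` gives 11500 nM. The gap from compound 2 to compound 1 lies within the usual scatter; the gap from compound 2 to compound 3 lies beyond it.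

Compound 4 `CC(c1ccc(-c2ccccc2)c(F)c1)c1nnc2n1N=C(c1ccc(F)cc1)CS2` differs from compound 2 by fluoro in place of trifluoromethoxy on an aromatic carbon. Going by the values given here, no measured pair shows this change, so no step can be read from the data. The expectation is a step of modest size or none beyond the scatter, if anything toward a higher number, so that the expected step from compound 2 to compound 4 is a 1.4-fold higher number from compound 2 to compound 4 (0.13 log units; within the scatter). Compound 4 is estimated at 6500 nM, within 2500 nM to 16000 nM.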

Compound 4, half-maximal inhibitory concentration: 8100 nM
Beside the measured number, compound 4's estimate is 1.2-fold (0.10 log units) below it, and the stated range covers the measured number.
By their numbers in this assay, from the lowest: compounds 2, 1, 4 and 3 (each within the scatter of the next, the first and the last beyond it).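

In this assay, going by these compounds alone, this is the first comparison that differs in one place: fluoro in place of trifluoromethoxy on an aromatic carbon, para to a large group, gives a 1.7-fold higher number from compound 2 to compound 4 (0.23 log units; within the scatter). The exchange at this position therefore leaves the number within the scatter, so this pair shows no clear dependence on which of the two groups is present. No measured evidence bears on this step.

On these data alone, whether an amine or a carboxylic acid at this position would give a step beyond the scatter stays open. As far as these compounds go, it also stays open whether the same exchange gives a similar step when the biphenyl part of compound 2 is replaced by another aryl group.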